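Swapping furan-2-yl for 4-methoxyphenyl on compound 1

A few compounds are considered here, and "the series" means these few. Any claim that something is new, unique, unknown or untested is made for them only; others in the source may bear on it.

In a functional assay on THP-1 cells (Homo sapiens) for inhibition, read by sulforhodamine B assay, with a stated time of 48 h, tested at 50 uM (a higher number here means more inhibition of growth at the concentration tested, a lower number less inhibition of growth), compound 1 (`COc1cc(/C=C/C(=O)/C=C/c2ccco2)ccc1OCc1cn(CCCOc2cc(=O)oc3ccccc23)nn1`) gives 57% and stands second highest of the three measured compounds. Compound 2 (`COc1cc(/C=C/C(=O)/C=C/c2cccs2)ccc1OCc1cn(CCOc2cc(=O)oc3ccccc23)nn1`) lies higher at 76% and compound 3 (`COc1cc(/C=C/C(=O)/C=C/c2ccccc2)ccc1OCc1cn(CCCCCOc2cc(=O)oc3ccccc23)nn1`) lower at 26%, both gaps beyond the scatter. Within the data shown here, neither differs from compound 1 in one place only, so no clean step exists. Compound 4 (`COc1ccc(/C=C/C(=O)/C=C/c2ccc(OCc3cn(CCCOc4cc(=O)oc5ccccc45)nn3)c(OC)c2)cc1`) carries one change from compound 1: 4-methoxyphenyl in place of furan-2-yl on a double-bonded chain carbon bound to a double-bonded chain carbon (4-methoxyphenyl in place of furan-2-yl). Compound 3 (26%) also lacks a five-membered aromatic ring with 1 hetero atom, which tilts the expectation slightly downward on thin evidence. A small fall in this assay is expected, not beyond the scatter (a number 9 percentage points lower from compound 1 to compound 4 (within the scatter)). Compound 4 is estimated at 48% (expected range 28% to 68%).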

Compound 4, percent growth inhibition at one concentration: 56%
The estimate for compound 4 lay 8 percentage points below the measured number; the range from low to high includes it.
By their numbers in this assay, from the lowest: compound 3; then compounds 4 and 1 (each within the scatter of the next); then compound 2.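

In this assay, among these compounds, the first clean step at this position reads a number 1 percentage points lower from compound 1 to compound 4 (within the scatter) and so shows that 4-methoxyphenyl can stand in place of furan-2-yl on a double-bonded chain carbon bound to a double-bonded chain carbon. For this one replacement, the five-membered aromatic ring with 1 hetero atom is not required to retain the growth inhibition of compound 1. No data on hand explain this result.

Open, from the compounds shown here alone, is whether an amine or a carboxylic acid on the same ring would keep this level. Going by these compounds, the separate contributions of the ring and the chain linking the core to the triazole also remain open.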